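Fluoro for Cyano: Expected Buffer Half-life of Compound 3

A few compounds are considered here, and "the series" means these few. Any claim that something is new, unique, unknown or untested is made for them only; others in the source may bear on it.

In an ADME assay for pharmacokinetics, read by LC-MS, in phosphate buffer, with a stated time of 72 h, at pH 7.4, tested at 250 uM (on this read-out higher numbers stand for a longer-lived compound and lower numbers for a shorter-lived compound), compound 1 `C#Cc1cc(C(F)(F)F)cc(C(F)(F)F)c1` gives > 50 h, a limit of the assay.
In this assay compound 2 `N#Cc1cc(C(F)(F)F)cc(C(F)(F)F)c1` gives > 50 h, also a limit of the assay.

Compound 2 therefore stands at the limit of > 50 h in this assay, at which 2 of the 2 values shown sit, so its true position is not fixed by the numbers. Compound 3 `Fc1cc(C(F)(F)F)cc(C(F)(F)F)c1` differs from it by fluoro in place of cyano on an aromatic carbon. For the measured compounds named here, the one measured step that bears on this, a step that the two limits leave unreadable from compound 1 to compound 2, is unreadable, so no size of step can be carried forward. Compound 3 is expected to sit again at the limit, with an estimated value of 120 h in a range from 50 h to 400 h. The expected step is a step that the limit leaves unreadable from compound 2 to compound 3, judged to lie within the scatter.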

Compound 3, half-life: > 50 h
Compound 3 gave a limit, no number (the forecaster's own chance of this, stated with the estimate: 85%); the middle value does not contradict the limit.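

No step can be read among compound 1, compound 2 and compound 3, as each gives only a limit in this assay: the limit of > 50 h in this assay, at which 3 of the 3 values shown sit.

The compounds shown leave open how long each truly lasts and whether ethynyl, cyano and fluoro differ at all.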